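Series notes: from compound 2 to compound 4

The compounds below may be only part of what the source reports. "The series", "measured", "known", "first", "only" and "open" are said of these compounds alone.

Measured so far:
compound 1, `CC(C)n1ncnc1-c1ccccc1NCC1=NCCN1`, 6.31 nM
compound 2, `CCn1cc(-c2ccccc2NCC2=NCCN2)cn1`, < 100000 nM (a limit)
compound 3, `Cc1ccc(-c2ccccc2NCC2=NCCN2)n1C`, 50.1 nM

In an in vitro functional assay on cells (Fibroblast) for agonist activity at Alpha-1A adrenergic receptor (Homo sapiens) (on this read-out higher numbers stand for an effect only at larger amounts of compound and lower numbers for an effect already at smaller amounts), compound 1 gives 6.31 nM and compound 3 gives 50.1 nM. For compound 2 the assay reports only a limit, < 100000 nM, and no number. This is the limit of < 100000 nM in this assay, at which 1 of the 3 values shown sits, so compound 2 cannot be placed against compound 1 or compound 3 on the scale of numbers, only at that limit.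

Compound 4, `Cn1cc(-c2ccccc2NCC2=NCCN2)cn1`, is not yet measured in this assay. It differs from compound 2 in one place: hydrogen in place of methyl on a saturated chain carbon bound to an aromatic nitrogen. Among the measured compounds shown here, no two measured compounds differ in a single place, so the size of such a change in this assay has no measured precedent. With compound 2 resting at a limit, the direction of the change cannot be read from the data either, and a step no larger than the scatter is the plainest expectation.

For compound 4 an effect is expected at 5000 nM, within a range from 300 nM to 80000 nM. The expected step that the limit leaves unreadable from compound 2 to compound 4 is an estimate only, and the assay may again report a limit for compound 4 rather than a number.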

Compound 4, half-maximal effective concentration: 398 nM
Estimate against measurement, compound 4: 13-fold (1.10 log units) above; the measured number falls inside the stated range.
By their numbers in this assay, from the lowest: compound 1; then compound 3; then compound 4.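

In this assay no step can be read from compound 2 to compound 4, because compound 2 stands only at a limit: the limit of < 100000 nM in this assay, at which 1 of the 4 values shown sits.

The compounds shown leave open how large a change hydrogen in place of methyl on a saturated chain carbon bound to an aromatic nitrogen brings, and in which direction.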